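Methoxy for Bromo on the Outer Aryl Ring

The source may hold more compounds than are shown below. What is called first, only, known or untested is meant among the compounds shown, and "the series" means these compounds.

Compound 1, `COc1nc(C(C)(C)C)ccc1[C@@H](c1ccccc1)[C@@](O)(CCN(C)C)c1cccc2ccccc12`, gives 27.6 ug/mL in a toxicity assay on Vero cells (Chlorocebus sabaeus) for cytotoxicity; on this read-out higher numbers stand for lower toxicity in this test and lower numbers for higher toxicity in this test. Compound 2, `COc1nc(-c2ccc(Br)cc2)ccc1[C@@H](c1ccccc1)[C@@](O)(CCN(C)C)c1cccc2ccccc12`, reaches only the limit of this assay, > 50 ug/mL. Compound 3, `COc1ncc(-c2ccccc2)cc1[C@@H](c1ccccc1)[C@@](O)(CCN(C)C)c1cc(F)cc(F)c1`, likewise reaches only the limit, > 50 ug/mL. Going by the values given here, the single measured step, an at least 1.8-fold higher number from compound 1 to compound 2 (0.25 log units; that floor lies within the scatter), is therefore bounded by a limit rather than fixed by a number, and compound 2 stands at that limit together with compound 3, as the limit of > 50 ug/mL in this assay, at which 2 of the 3 values shown sit, shows. Compound 4, `COc1ccc(-c2ccc([C@@H](c3ccccc3)[C@@](O)(CCN(C)C)c3cccc4ccccc34)c(OC)n2)cc1`, differs from compound 2 by methoxy in place of bromo on an aromatic carbon. Among the compounds with values here, no measured step concerns this exact change; the step from compound 1 to compound 2 exchanges the whole 4-bromophenyl and only places compound 2 at the limit. Because both aryl-bearing compounds sit at the limit (the limit of > 50 ug/mL in this assay, at which 2 of the 3 values shown sit), the account expects compound 4 to stay near that limit, with the step that the limit leaves unreadable from compound 2 to compound 4 expected to lie within the scatter. Compound 4 is accordingly estimated at 60 ug/mL, between 30 ug/mL and 120 ug/mL.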

Compound 4, half-maximal cytotoxic concentration: > 50 ug/mL
Compound 4: only a limit was reported; the forecaster's own chance of this, stated with the estimate: 70%; the middle value does not contradict the limit.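

With methoxy in place of bromo on the outer aryl ring, compound 4 also ends at a limit in this assay, > 50 ug/mL, and the step from compound 2 cannot be read. Against tert-butyl, the 4-methoxyphenyl group gives an at least 1.8-fold higher number from compound 1 to compound 4 (0.25 log units; that floor lies within the scatter), so this floor does not separate it from compound 1 any more firmly than the floor for 4-bromophenyl did. A second substituent on this ring has now been read at the limit, which has become the most common result among the compounds shown: the limit of > 50 ug/mL in this assay, at which 3 of the 4 values shown sit.

As far as these compounds go, how much room lies beyond the limit for compound 2 and compound 4 stays open, so any difference between bromo and methoxy remains hidden. Also open, from the compounds shown here alone, is whether an amine or a carboxylic acid at this place on the outer aryl ring would stay at the limit.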